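Cytotoxicity series: ethynyl versus phenyl on a nucleoside core

The source may report more compounds than this note shows. Statements on the series, on what has been measured and on what is new or still open speak of the compounds shown alone.

Compound 3 `CNc1ncnc2c1c(-c1ccccc1)cn2[C@@H]1O[C@H](CO)[C@@H](O)[C@H]1O`, compound 2 `COc1ncnc2c1c(-c1ccccc1)cn2[C@@H]1O[C@H](CO)[C@@H](O)[C@H]1O` and compound 1 `C#Cc1cn([C@@H]2O[C@H](CO)[C@@H](O)[C@H]2O)c2ncnc(NC)c12` were all run in an ADME assay on MRC5 cells (Homo sapiens), read by MTT assay, with a stated time of 72 h; on this read-out lower numbers stand for stronger inhibition and higher numbers for weaker inhibition. In this assay compound 3 gives > 100000 nM, a limit of the assay rather than a number. Compound 2 likewise gives > 100000 nM, again a limit. Compound 1 gives > 100000 nM, also a limit. With all three results sitting at the same limit, (the limit of > 100000 nM in this assay, at which 3 of the 3 values shown sit), the step that the two limits leave unreadable from compound 3 to compound 1 and the step that the two limits leave unreadable from compound 2 to compound 3 cannot be given a size.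

The change from compound 3 to compound 1 is ethynyl in place of phenyl on an aromatic carbon. Compound 4 `C#Cc1cn([C@@H]2O[C@H](CO)[C@@H](O)[C@H]2O)c2ncnc(OC)c12` is not yet measured; it differs from compound 2 by ethynyl in place of phenyl on an aromatic carbon, the same change, at a place described in the same words. The two cores differ by methoxy in place of methylamino on an aromatic carbon.

For compound 4 in this assay the expectation rests on compound 2, whose result > 100000 nM is a limit, and on compound 1, whose result > 100000 nM is also a limit, so the expected step that the limit leaves unreadable from compound 2 to compound 4 is one that cannot be read as a number. Compound 4 is therefore estimated at 150000 nM, with a range from 60000 nM to 500000 nM, and the most likely outcome is that this assay again reports only a limit for compound 4.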

Compound 4, half-maximal inhibitory concentration: > 100000 nM
Compound 4: a limit, no number; the forecaster's own chance of this, stated with the estimate: 90%; the middle value is on the limit's open side.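

Compound 4 gives > 100000 nM in this assay, a limit and not a number. Its steps from compound 2 and from compound 1 cannot be read, so neither ethynyl in place of phenyl nor methoxy in place of methylamino gains a size: the limit of > 100000 nM in this assay, at which 4 of the 4 values shown sit.

The compounds shown leave open how any of these changes acts on the read-out in this assay, since none gives a value inside the measured range.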